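A few compounds are considered here, and "the series" means these few. Any claim that something is new, unique, unknown or untested is made for them only; others in the source may bear on it.

Compound 1 `Cc1ccccc1NS(=O)(=O)c1ccc(NC(=O)NCCCCl)cc1` and compound 2 `CCc1ccccc1NS(=O)(=O)c1ccc(NC(=O)NCCCCl)cc1` share one core, while compound 3 `CCNC(=O)Nc1cccc(S(=O)(=O)Nc2ccccc2C)c1` and compound 4 `CCNC(=O)Nc1cccc(S(=O)(=O)Nc2ccccc2CC)c1` share another; the difference between the two cores is not broken down here. In a functional assay on M21 cells (Homo sapiens) for cytotoxicity, read by sulforhodamine B assay, with a stated time of 48 h (on this read-out higher numbers stand for weaker inhibition and lower numbers for stronger inhibition), compound 1 gives only a limit, > 200000 nM. Compound 2 likewise gives only a limit in this assay, namely > 200000 nM. The change between them is methyl in place of hydrogen on a saturated chain carbon bound to an aromatic carbon, and it leaves a step that the two limits leave unreadable from compound 1 to compound 2, since both values sit at the limit of > 200000 nM in this assay, at which 2 of the 3 values shown sit. Among the measured compounds shown here, compound 3 gives 131000 nM in this assay, the only number among the three measured compounds. Compound 4 carries the same kind of change on the other core, (methyl in place of hydrogen on a saturated chain carbon bound to an aromatic carbon), at the same place, a saturated chain carbon bound to an aromatic carbon. The earlier step is unreadable and so offers no measure of size; the expectation therefore rests on compound 3 alone, which gave 131000 nM, and the step is estimated as a 1.1-fold higher number from compound 3 to compound 4 (0.06 log units; within the scatter). Compound 4 is accordingly expected to give about 150000 nM in this assay, within a range from 60000 nM to 400000 nM.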

Compound 4, half-maximal inhibitory concentration: > 100000 nM
Compound 4: only a limit was reported (the forecaster's own chance of this, stated with the estimate: 35%); the middle value does not contradict the limit.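

No size can be read for the change from compound 3 to compound 4, since compound 4 is reported only as a limit: the limit of > 100000 nM in this assay, at which 1 of the 4 values shown sits.

The compounds shown leave open whether 2-ethylphenyl in place of 2-methylphenyl alters the cytotoxicity read-out on either core, as compound 1, compound 2 and compound 4 all give limits rather than numbers.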